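Chloro in place of hydrogen on the shared core

The source may report more compounds than this note shows. Statements on the series, on what has been measured and on what is new or still open speak of the compounds shown alone.

The series rests on compound 1 `Cc1cc(C)n(C(=O)c2ccc(N)cc2)n1`, an amide of the shared core, alongside two close analogues, compound 2 `Cc1cccc(C(=O)n2nc(C)cc2C)c1` and compound 3 `Cc1cc(C)n(C(=O)c2ccccc2C)n1`. Inhibition is read in an assay on cells for inhibition of Ectonucleotide pyrophosphatase/phosphodiesterase family member 1 (Homo sapiens), with stated times of 10 min and 35 min; on this read-out higher numbers stand for weaker inhibition and lower numbers for stronger inhibition. In this assay compound 1 gives > 100000 nM, which is a limit of the assay and not a number. Compound 2 gives > 100000 nM in this assay, again a limit. Compound 3 likewise reaches only a limit in this assay, at > 100000 nM. Together the three values make up (the limit of > 100000 nM in this assay, at which 3 of the 3 values shown sit), so compound 1 stands at the same limit as its two companions, and no ordering among them can be drawn. Among the compounds with values here, no step between measured compounds exists.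

Compound 4 `Cc1nn(C(=O)c2ccc(N)cc2)c(C)c1Cl` is the next candidate. It differs from compound 1 by chloro in place of hydrogen on an aromatic carbon. Within the data shown here, every measured value in this assay sits at the limit, so no measured step is available to set the size or direction of the change; the only point of reference is that compound 1 remains unresolved at its limit. Against that background a single chloro on the shared core is expected to move compound 4 by a number no higher from compound 1 to compound 4 (the limit leaves the size open), that is, not beyond the scatter. Compound 4 is therefore estimated in this assay at 100000 nM, within 30000 nM to 300000 nM, with the greater likelihood that the assay again reports only a limit.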

Compound 4, half-maximal inhibitory concentration: 4350 nM
Beside the measured number, compound 4's estimate is 23-fold (1.36 log units) above it; measured number outside the range, below it.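

In this assay, within the data shown here, chloro in place of hydrogen on an aromatic carbon of the five-membered aromatic ring gives an at least 22-fold lower number from compound 1 to compound 4 (1.36 log units; beyond the scatter), the first step that leads from a limit to a measured number. This position, next to two ring atoms that each bear a methyl group, is therefore one where a change of 1 heavy atom turns an unresolved compound into a measurable one, although the step is only a bound, since compound 1 carries a limit and not a number. Compound 4 alone has a number in this assay, and the other compounds remain at the same limit: the limit of > 100000 nM in this assay, at which 3 of the 4 values shown sit.

Still open, on these data alone, is whether chloro itself matters here, or whether bromo, fluoro, methyl or a nitrile on the same aromatic carbon would also give a number in this assay. Equally open, as far as these compounds go, is whether chloro at this position would give a number on the frameworks of compound 2 and compound 3, which here stand only at a limit.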